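Fluoro for chloro: the step from compound 1 to compound 4

The compounds below may be only part of what the source reports. "The series", "measured", "known", "first", "only" and "open" are said of these compounds alone.

Measured so far in a functional assay on DU-145 cells (Homo sapiens) for inhibition, read by trypan blue exclusion, with a stated time of 96 h; a higher number here means a weaker inhibitor of growth, a lower number a stronger inhibitor of growth:
- compound 1 `O=C(/C(=C\c1ccc(Cl)c([N+](=O)[O-])c1)S(=O)(=O)c1ccc(Br)cc1)c1ccc(Br)cc1`: 10000 nM
- compound 2 `O=C(/C(=C\c1cccc(Cl)c1Cl)SCc1ccc(Cl)cc1)c1ccc(Br)cc1`: 10000 nM
- compound 3 `O=C(/C(=C\c1ccc(Cl)c([N+](=O)[O-])c1)Sc1ccc(Br)cc1)c1ccc(Br)cc1`: 10000 nM

Compound 1 stands level with compounds 2 and 3 in this assay; none of the three is separated from another by more than the scatter. Going by the values given here, the one step that can be followed within one place, from compound 1 to compound 3, gives no change at the digits printed from compound 1 to compound 3 (within the scatter), so exchanging the sulfonyl for the sulfanyl link on the chain carbon leaves the read-out where it was.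

Compound 4 `O=C(/C(=C\c1ccc(F)c([N+](=O)[O-])c1)S(=O)(=O)c1ccc(Br)cc1)c1ccc(Br)cc1` has not yet been measured. It differs from compound 1 as follows: fluoro in place of chloro on an aromatic carbon

Among the compounds with values here, no measured pair changes a halogen on the 4-chloro-3-nitrophenyl ring, so no step here bears directly on this exchange. What the series does show is that a change of greater weight, at the chain sulfur, gave no change at the digits printed from compound 1 to compound 3 (within the scatter), and that compound 2, with a different substitution on its aryl ring, sits at 10000 nM. Nothing in these numbers points to movement in either direction.

Compound 4 is therefore expected to give 10000 nM, with a range from 5000 nM to 20000 nM, meaning an expected step of no change at the digits printed from compound 1 to compound 4 (within the scatter), none beyond the scatter.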

Compound 4, concentration for 50% growth inhibition: 25000 nM
Beside the measured number, compound 4's estimate is 2.5-fold (0.40 log units) below it; measured number above the stated range.
By their numbers in this assay, from the lowest: compounds 1, 2 and 3 (each within the scatter of the next); then compound 4.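

In this assay, the ring halogen proves to be a position that registers in the read-out: chloro to fluoro on the aromatic carbon ortho to a nitro group and para to a large group gives a 2.5-fold higher number from compound 1 to compound 4 (0.40 log units; beyond the scatter) and so a weaker inhibitor of growth. This is a single-atom exchange with no change in the hydrogen-bond donor or acceptor count, no ring and no net charge, yet it lies beyond the scatter, whereas the exchange at the chain sulfur gives no change at the digits printed from compound 1 to compound 3 (within the scatter) and does not. Among the single-place steps shown, the 4-chloro-3-nitrophenyl to 4-fluoro-3-nitrophenyl change is therefore the only one that separates two compounds, and nothing measured here accounts for that separation.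

The compounds shown leave open whether chloro is specifically favoured at this position or fluoro specifically disfavoured, since a single pair cannot separate the two; bromo, methyl, methoxy or an amine on the same carbon would give the position more than two points. Also open, going by these compounds, is whether the same chloro to fluoro exchange moves the read-out in the sulfanyl-linked compound 3, or whether it holds only with the sulfonyl link of compound 1.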